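Chloro Added to the Aryl Ether of Compound 2

The compounds below may be only part of what the source reports. "The series", "measured", "known", "first", "only" and "open" are said of these compounds alone.

Measured compounds:
compound 1, `O=C(O)CCc1ccc(OCc2nc(-c3cccc(C(F)(F)F)c3)no2)c(Cl)c1`, 30100 nM
compound 2, `COc1cccc(-c2noc(COc3ccc(CCC(=O)O)cc3)n2)c1`, 2670 nM

In a functional assay on CHO cells for agonist activity at Free fatty acid receptor 1 (Homo sapiens), read by FLIPR and calcium flux, in the presence of a further agent that is not named here (on this read-out higher numbers stand for an effect only at larger amounts of compound and lower numbers for an effect already at smaller amounts), compound 2 gives the lower of the two numbers; compound 1 stands well beyond the scatter above it. Compound 3, `COc1cccc(-c2noc(COc3ccc(CCC(=O)O)cc3Cl)n2)c1`, differs from compound 2 by chloro in place of hydrogen on an aromatic carbon. Among the measured compounds shown here, no measured pair shows this change alone, so the expected step from compound 2 to compound 3 in this assay is set at a 1.9-fold higher number from compound 2 to compound 3 (0.27 log units; within the scatter), modestly upward. Compound 3 is therefore expected near 5000 nM, between 1500 nM and 15000 nM.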

Compound 3, half-maximal effective concentration: 3000 nM
The estimate for compound 3 lay 1.7-fold (0.22 log units) above the measured number; the measured number falls inside the stated range.
By their numbers in this assay, from the lowest: compounds 2 and 3 (each within the scatter of the next); then compound 1.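

In this assay, chloro on this aromatic carbon, ortho to a large group and meta to a 2-carboxyethyl group, is tolerated on the methoxy series (a 1.1-fold higher number from compound 2 to compound 3 (0.05 log units; within the scatter)). With chloro held constant, the substituent on the other aromatic ring can now be read alone, since methoxy in place of trifluoromethyl gives a clear step (a 10-fold lower number from compound 1 to compound 3 (1.00 log units; beyond the scatter)), which the earlier pair, differing in two places, could not isolate. Nothing measured here explains either step. On these data alone, whether fluoro or methyl would be tolerated on this carbon remains open, as does whether chloro would read the same with trifluoromethyl replaced by an amine.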